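Moving one hydroxy from compound 3 to compound 4

This account rests on a few compounds, and the source may have more. Where it says the series, first, only, none or still open, it means among the compounds named here.

Compound 1 `O=C(/C=C/c1cccc(O)c1)CC(=O)/C=C/c1cccc(O)c1O` gives 29000 nM
Compound 2 `O=C(/C=C/c1cc(O)ccc1O)CC(=O)/C=C/c1cccc(O)c1O` gives 27000 nM
Compound 3 `O=C(/C=C/c1ccccc1O)CC(=O)/C=C/c1cc(O)ccc1O` gives 48000 nM

In a functional assay, with a stated time of 30 min (on this read-out higher numbers stand for weaker inhibition and lower numbers for stronger inhibition), compound 3 at 48000 nM sits within the scatter of both compound 1 and compound 2, so the three cannot be ranked. Compound 4 `O=C(/C=C/c1cccc(O)c1)CC(=O)/C=C/c1cc(O)ccc1O` is compound 3 with one group exchanged: 3-hydroxyphenyl in place of 2-hydroxyphenyl on a double-bonded chain carbon bound to a double-bonded chain carbon with 3-hydroxyphenyl in place of 2-hydroxyphenyl on a double-bonded chain carbon bound to a double-bonded chain carbon. Within the data shown here, two measured steps bear on it, though neither is this same exchange: a 1.1-fold lower number from compound 1 to compound 2 (0.03 log units; within the scatter) and a 1.8-fold higher number from compound 2 to compound 3 (0.25 log units; within the scatter) both stay within the scatter, although each adds or removes a hydroxy. No step beyond the scatter is therefore expected in this assay, and the estimated 1.4-fold lower number from compound 3 to compound 4 (0.14 log units; within the scatter) is small. For compound 4 the estimate is 35000 nM and 17000 nM to 70000 nM is the expected range.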

Compound 4, half-maximal inhibitory concentration: 88000 nM
The estimate for compound 4 lay 2.5-fold (0.40 log units) below the measured number; the measured number lies above the stated range.
By their numbers in this assay, from the lowest: compounds 2, 1, 3 and 4 (each within the scatter of the next, the first and the last beyond it).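

In this assay, 3-hydroxyphenyl in place of 2-hydroxyphenyl gives a 1.8-fold higher number from compound 3 to compound 4 (0.26 log units; within the scatter), so this exchange alone cannot be told from scatter. Among these compounds, compound 4 nevertheless gives the first steps beyond the scatter: hydrogen in place of hydroxy on an aromatic carbon gives a 3.3-fold higher number from compound 2 to compound 4 (0.51 log units; beyond the scatter), and 2,5-dihydroxyphenyl in place of 2,3-dihydroxyphenyl gives a 3.0-fold higher number from compound 1 to compound 4 (0.48 log units; beyond the scatter). No evidence is available that explains these differences. On these data alone, whether an amine or a carboxylic acid in place of hydroxy on an aromatic carbon would give a lower number remains open.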